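The source may hold more compounds than are shown below. What is called first, only, known or untested is meant among the compounds shown, and "the series" means these compounds.

The measured compounds and their values in a functional assay on Malme-3M cells (Homo sapiens) for inhibition, read by sulforhodamine B assay, with a stated time of 48 h, tested at 0.01 uM; a lower number here means a stronger effect, a higher number a weaker effect of the compound at the concentration tested:
Compound 1 `COc1cc(Cl)cc(-c2nn(-c3cccc(NC(=O)Nc4ccc(Cl)c(C(F)(F)F)c4)c3)cc2-c2ccncc2)c1`: 94%
Compound 2 `COc1cc(Cl)cc(-c2nn(-c3cccc(NC(=O)Nc4ccc(Cl)c(Cl)c4)c3)cc2-c2ccncc2)c1`: 92%
Compound 3 `COc1cc(Cl)cc(-c2nn(-c3cccc(NC(=O)Nc4cccc(C(F)(F)F)c4)c3)cc2-c2ccncc2)c1`: 95%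

Compound 3 sits within the scatter of both of the others: a number 1 percentage points higher from compound 1 to compound 3 (within the scatter) and a number 3 percentage points higher from compound 2 to compound 3 (within the scatter), and likewise a number 2 percentage points lower from compound 1 to compound 2 (within the scatter). Compound 4 `COc1cc(Cl)cc(-c2nn(-c3cccc(NC(=O)c4cccc(C(F)(F)F)c4)c3)cc2-c2ccncc2)c1` departs from compound 3 by 3-(trifluoromethyl)phenyl in place of (3-(trifluoromethyl)phenyl)amino on a carbonyl carbon. None of the three measured steps touches this part of the molecule; all of them concern the substituents of the ring on the amide-type nitrogen, and all lie within the scatter. There is thus no measured guide to this change, and the expectation is of no step beyond the scatter, a number 5 percentage points lower from compound 3 to compound 4 (within the scatter). For compound 4 in this assay the estimate is 90%, with a range from 72% to 100%.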

Compound 4, a percentage reported as activity, at one concentration (the size of the read-out at that concentration, not a potency): 58%
The estimate for compound 4 lay 32 percentage points above the measured number; the whole stated range lies above it.
By their numbers in this assay, from the lowest: compound 4; then compounds 2, 1 and 3 (each within the scatter of the next).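

In this assay the carbonyl carbon turns out to be a place that responds, unlike the substituents of the outer ring: 3-(trifluoromethyl)phenyl in place of (3-(trifluoromethyl)phenyl)amino gives a number 37 percentage points lower from compound 3 to compound 4 (beyond the scatter) and thus a stronger effect at the concentration tested. The other two comparisons agree, with a number 34 percentage points lower from compound 2 to compound 4 (beyond the scatter) and a number 36 percentage points lower from compound 1 to compound 4 (beyond the scatter), though each of these also alters the outer ring. No measurement here accounts for the change. Still open, on these data alone, is whether a methylene group or a longer chain on the carbonyl carbon would do the same, and whether the 3,4-dichlorophenyl ring, placed directly there, would match compound 4.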